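Methyl on the piperidine ring: from compound 3 to compound 4

The source may hold more compounds than are shown below. What is called first, only, known or untested is meant among the compounds shown, and "the series" means these compounds.

Compound 3 `COc1ccc(-n2nc(C(=O)Nc3ccc(Oc4ccnc5cc(OCCCN6CCCCC6)c(OC)cc45)c(F)c3)c(C)cc2=O)cc1` gives 1500 nM in a functional assay on A549 cells (Homo sapiens) for inhibition, read by MTT assay, with a stated time of 72 h (a lower number here means a stronger inhibitor, a higher number a weaker inhibitor), the second highest of the three numbers measured. Going by the values given here, its nearest neighbour is compound 2 `COc1ccc(-n2nc(C(=O)Nc3ccc(Oc4ccnc5cc(OCCCN6CCCC6)c(OC)cc45)c(F)c3)c(C)cc2=O)cc1`, which gives 2770 nM; the only measured step that differs in one place, a 1.8-fold lower number from compound 2 to compound 3 (0.27 log units; within the scatter), exchanged the ring on the chain and stayed within the scatter. Compound 1 `COc1cc2c(Oc3ccc(NC(=O)c4nn(-c5cccc(F)c5)c(=O)cc4C)cc3F)ccnc2cc1OCCCN1CCC(C)CC1` carries the 4-methylpiperidin-1-yl group but differs from compound 3 elsewhere as well; in this assay compound 1 gives 250 nM. The unmeasured compound 4 `COc1ccc(-n2nc(C(=O)Nc3ccc(Oc4ccnc5cc(OCCCN6CCC(C)CC6)c(OC)cc45)c(F)c3)c(C)cc2=O)cc1` differs from compound 3 by methyl in place of hydrogen on a saturated ring carbon. Among the compounds with values here, no measured pair isolates this change, and the one step that touches the same ring, a 1.8-fold lower number from compound 2 to compound 3 (0.27 log units; within the scatter), was small. The step of a 1.5-fold lower number from compound 3 to compound 4 (0.18 log units; within the scatter) is therefore expected to be small, if anything toward a lower number, with a wide margin. Compound 4 is estimated to give 1000 nM in this assay, within a range from 350 nM to 3000 nM.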

Compound 4, half-maximal inhibitory concentration: 1100 nM
Estimate against measurement, compound 4: 1.1-fold (0.04 log units) below; low and high end bracket the measured number.
By their numbers in this assay, from the lowest: compound 1; then compounds 4, 3 and 2 (each within the scatter of the next, the first and the last beyond it).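

In this assay, going by these compounds alone, methyl in place of hydrogen on the saturated ring carbon, three ring bonds from the ring nitrogen, stays within the scatter (a 1.4-fold lower number from compound 3 to compound 4 (0.13 log units; within the scatter)), yet the full exchange of pyrrolidin-1-yl for 4-methylpiperidin-1-yl gives the first modest step beyond the scatter at this end of the chain (a 2.5-fold lower number from compound 2 to compound 4 (0.40 log units; beyond the scatter)). The pair of compound 1 and compound 4, which differ only on the aromatic nitrogen, now places a modest step at 4-methoxyphenyl in place of 3-fluorophenyl (a 4.4-fold higher number from compound 1 to compound 4 (0.64 log units; beyond the scatter)), so that the gap of compound 1 to the others no longer has to be read at the piperidine ring. No evidence at hand bears on what lies behind these steps.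

The compounds shown leave open whether an ethyl or a hydroxyl on the same ring carbon would move the number further. They also leave open whether 4-methylpiperazin-1-yl on the chain, or 3-fluorophenyl together with piperidin-1-yl, would do so.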